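Amino in place of methoxy on compound 3

The source may report more compounds than this note shows. Statements on the series, on what has been measured and on what is new or still open speak of the compounds shown alone.

In a functional assay on HT-29 cells (Homo sapiens) for cytotoxicity, read by MTT assay, with a stated time of 3 days (on this read-out higher numbers stand for weaker inhibition and lower numbers for stronger inhibition), compound 3 (`COc1cccc(-c2ccc(O)cc2)c1`) gives 24 ug/mL, which lies within the scatter of compound 1 (`COc1cccc(-c2cccc(O)c2)c1`) at 16 ug/mL. Compound 2 (`Oc1ccc(-c2cccc(O)c2)cc1`) gives a clearly lower number, 3.4 ug/mL. Within the data shown here, the only measured step is a 7.1-fold higher number from compound 2 to compound 3 (0.85 log units; beyond the scatter), with methyl in place of hydrogen on an oxygen on an aromatic ring. That modest step lies beyond the scatter.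

Compound 4 (`Nc1cccc(-c2ccc(O)cc2)c1`) carries amino in place of methoxy on an aromatic carbon, meta to a group of 7 heavy atoms: amino in place of methoxy on an aromatic carbon. Among the measured compounds shown here, no measured compound carries amino, so the guide is indirect. For the measured compounds named here, the step of a 7.1-fold higher number from compound 2 to compound 3 (0.85 log units; beyond the scatter) is the only measured change involving this methoxy, so a move to a lower number in this assay is expected, though smaller than that step. The expected step is a 2.7-fold lower number from compound 3 to compound 4 (0.43 log units; beyond the scatter). For compound 4 the estimated value is 9 ug/mL, with an expected range of 3.5 ug/mL to 22 ug/mL.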

Compound 4, half-maximal inhibitory concentration: 5.4 ug/mL
Compound 4: middle estimate off by 1.7-fold (0.22 log units), on the high side; the range from low to high includes it.
By their numbers in this assay, from the lowest: compounds 2 and 4 (each within the scatter of the next); then compounds 1 and 3 (each within the scatter of the next).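

In this assay, among these compounds, amino in place of methoxy on an aromatic carbon, meta to a group of 7 heavy atoms, gives a 4.4-fold lower number from compound 3 to compound 4 (0.65 log units; beyond the scatter) and thus a second replacement of methoxy at this position with a step beyond the scatter, where the earlier compounds offered only hydroxy. Amino and hydroxy are not separated here, as amino in place of hydroxy gives a 1.6-fold higher number from compound 2 to compound 4 (0.20 log units; within the scatter) and that step lies within the scatter. No evidence bears on why the number follows these groups.

As far as these compounds go, whether the position tolerates a larger nitrogen group, such as a dimethylamino or acetamide group, remains open. So does the outcome with a carboxylic acid or a halogen such as fluorine on the same aromatic carbon.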